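The source may report more compounds than this note shows. Statements on the series, on what has been measured and on what is new or still open speak of the compounds shown alone.

Compound 1 `O=C(Nc1ccccc1)c1c(NO)cc(-c2ccccc2)oc1=O` gives 11600 nM in an ADME assay on Huh-7 cells (Homo sapiens) for cytotoxicity, read by a luciferase reporter and WST assay, with a stated time of 3 days; on this read-out higher numbers stand for lower toxicity in this test and lower numbers for higher toxicity in this test. Compound 2 `Cc1ccc(-c2cc(NO)c(C(=O)Nc3ccccc3)c(=O)o2)cc1` gives > 20000 nM in this assay, which is a limit of the assay and not a number.

Among the measured compounds shown here, compound 1 therefore holds the only plain number among the two values shown; the other value is a limit (the limit of > 20000 nM in this assay, at which 1 of the 2 values shown sits). For the measured compounds named here, the single measured step, an at least 1.7-fold higher number from compound 1 to compound 2 (0.23 log units; that floor lies within the scatter), reads as a floor that lies within the usual scatter, and it concerns a methyl on the phenyl attached to the core, not the anilide side.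

Compound 3 `O=C(Nc1ccc(F)cc1)c1c(NO)cc(-c2ccccc2)oc1=O` differs from compound 1 by fluoro in place of hydrogen on an aromatic carbon. No measured step touches this position, and the only step shown, from a different ring, stays within the scatter. Compound 3 is therefore expected to show no step beyond the scatter, a 1.0-fold higher number from compound 1 to compound 3 (0.01 log units; within the scatter). The estimate for compound 3 in this assay is 12000 nM, with a range from 6000 nM to 24000 nM.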

Compound 3, half-maximal cytotoxic concentration: > 20000 nM
Compound 3 ended at the assay's limit; the forecaster's own chance of this, stated with the estimate: 25%; middle value at least 1.6-fold (0.22 log units) away from the limit.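

Going from anilino to (4-fluorophenyl)amino in this assay gives the first measured step at this position, an at least 1.7-fold higher number from compound 1 to compound 3 (0.23 log units; that floor lies within the scatter), and it shows no lower number for the fluoro compound, although the size of the step stays unknown. For compound 3 the value > 20000 nM is a limit of the assay and not a number. The methyl of compound 2 and the fluoro of compound 3, which sit on different rings, now end alike: the limit of > 20000 nM in this assay, at which 2 of the 3 values shown sit.

The compounds shown leave open whether a different group at this place, such as an amine, a methoxy group or a carboxylic acid, would give a number clearly lower than that of compound 1. With two of the three values at a limit, they also give the true size of neither step.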